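The source may report more compounds than this note shows. Statements on the series, on what has been measured and on what is new or still open speak of the compounds shown alone.

Compound 3, with the structure `CO[C@H]1C[C@H](Oc2cc(F)c(F)c(-c3cc(F)c(OCCC(C)(C)C(=O)O)c(F)c3)c2)C1`, was tested in a functional assay on CHO cells for agonist activity at Free fatty acid receptor 1 (Homo sapiens), read by calcium flux (a lower number here means that less compound is needed, a higher number that more compound is needed for the effect), and gave only a limit, > 100000 nM, not a measured number. Compound 1, with the structure `CO[C@H]1C[C@H](Oc2cc(F)c(F)c(-c3ccc4c(c3)CC[C@H](CCC(=O)O)O4)c2)C1`, sits at the same limit in this assay, > 100000 nM. Compound 2, with the structure `CC(C)Nc1ccccc1-c1cc(F)c(OCCCC(=O)O)c(F)c1`, likewise reached only the limit in this assay, > 100000 nM. Where compound 3 stands is therefore plain: it has no measurable activity, and none of the other two compounds shows one either, as all three values sit at the limit of > 100000 nM in this assay, at which 3 of the 3 values shown sit.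

Compound 4, with the structure `CO[C@H]1C[C@H](Oc2cc(F)c(F)c(-c3cc(F)c(OCCCCCCCC(=O)O)c(F)c3)c2)C1`, differs from compound 3 by a single change: 5-carboxypentyl in place of 1-carboxy-1-methylethyl on a saturated chain carbon, two bonds along the chain from an oxygen on an aromatic ring. Within the data shown here, no measured pair shows what such an exchange does. The account expects the step from compound 3 to compound 4, an at least 3.3-fold lower number from compound 3 to compound 4 (0.52 log units; beyond the scatter), to fall toward lower concentrations, though it may also stay at the limit. For compound 4 the estimate in this assay is 30000 nM, within a range from 3000 nM to 100000 nM.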

Compound 4, half-maximal effective concentration: 3480 nM
The estimate for compound 4 lay 8.6-fold (0.94 log units) above the measured number; the range from low to high includes it.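

Among these compounds, compound 4 is the only one of the four compounds with a measured number in this assay, and a single exchange at this position brings it there: 5-carboxypentyl in place of 1-carboxy-1-methylethyl gives an at least 28-fold lower number from compound 3 to compound 4 (1.45 log units; beyond the scatter). Compound 3 gives only a limit, so this step has a bound and not an exact size. The position therefore responds to change and the core of compound 3 can carry activity, which the earlier compounds could not show: the limit of > 100000 nM in this assay, at which 3 of the 4 values shown sit.

On these data alone, both chain length and the two methyl groups on the carbon bearing the carboxylic acid change in this one exchange, so it remains open which of them carries the step. As far as these compounds go, whether a 3-carboxypropyl group or a still longer chain at this place would lower the number further is also open.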